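The source may hold more compounds than are shown below. What is called first, only, known or untested is meant among the compounds shown, and "the series" means these compounds.

Notes on the series in a functional assay on SK-OV-3 cells (Homo sapiens) for inhibition; a higher number here means a weaker inhibitor, a lower number a stronger inhibitor: compound 1 `CCCCCOC(=O)Nc1nc(=O)n(C2O[C@H](C(=O)O)[C@@H](O)[C@H]2O)cc1F` gives 0.03 ug/mL, compound 2 `C=CCOC(=O)Nc1nc(=O)n(C2O[C@H](C(=O)O)[C@@H](O)[C@H]2O)cc1F` gives 0.008 ug/mL and compound 3 `C#CCOC(=O)Nc1nc(=O)n(C2O[C@H](C(=O)O)[C@@H](O)[C@H]2O)cc1F` gives 0.005 ug/mL. Compound 3 stands at the low end of these numbers, level with its nearest neighbour: a 1.6-fold lower number from compound 2 to compound 3 (0.20 log units; within the scatter) stays within the scatter, while a 6.0-fold lower number from compound 1 to compound 3 (0.78 log units; beyond the scatter) goes beyond it. Compound 4 `O=C(Nc1nc(=O)n(C2O[C@H](C(=O)O)[C@@H](O)[C@H]2O)cc1F)Oc1ccccc1` carries phenyl in place of propargyl on an oxygen next to a carbonyl group. The measured steps at this place are modest, with a 3.8-fold lower number from compound 1 to compound 2 (0.57 log units; beyond the scatter) alongside the two above. Among the measured compounds shown here, no measured compound has a ring there, so the guide is loose. In this assay, a modest move to a higher number is expected, with the estimated step being a 3.0-fold higher number from compound 3 to compound 4 (0.48 log units; beyond the scatter). For compound 4 the estimated value is 0.015 ug/mL, with an expected range of 0.004 ug/mL to 0.06 ug/mL.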

Compound 4, half-maximal inhibitory concentration: 0.12 ug/mL
The estimate for compound 4 lay 8.0-fold (0.90 log units) below the measured number, and the stated range ends below it.
By their numbers in this assay, from the lowest: compounds 3 and 2 (each within the scatter of the next); then compound 1; then compound 4.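

In this assay, among the compounds shown here, phenyl on this oxygen gives the highest number so far: against the two unsaturated chains, a 24-fold higher number from compound 3 to compound 4 (1.38 log units; beyond the scatter) and a 15-fold higher number from compound 2 to compound 4 (1.18 log units; beyond the scatter) are both large steps, and against pentyl, a 4.0-fold higher number from compound 1 to compound 4 (0.60 log units; beyond the scatter) is a modest one. A ring here therefore costs more than any chain shown, and the saturated pentyl is no longer the worst group at this place. Nothing available accounts for this loss.

On these data alone, whether the higher number goes with the ring itself or with its direct attachment to the oxygen stays open. Benzyl and cyclohexyl at this place would separate those two readings.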